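The compounds below may be only part of what the source reports. "The series", "measured", "known", "first", "only" and "open" are said of these compounds alone.

Measured so far:
compound 1, `COc1ccc(C2=NN(C3=NC(=O)/C(=C4\C(=O)Nc5ccc(Br)cc54)S3)C(c3ccc(OC)cc3)C2)cc1`, 380 nM in a functional assay on cells (Cancer cell lines, Homo sapiens) for cytotoxicity, read by sulforhodamine B assay, with a stated time of 48 h; a higher number here means a weaker inhibitor of growth, a lower number a stronger inhibitor of growth
compound 2, `COc1ccc(C2=NN(C3=NC(=O)/C(=C4\C(=O)Nc5ccc(Cl)cc54)S3)C(c3ccc(OC)cc3)C2)cc1`, 390 nM
compound 3, `CN(C)c1ccc(C2CC(c3ccccc3)=NN2C2=NC(=O)/C(=C3\C(=O)Nc4ccc(Br)cc43)S2)cc1`, 450 nM

All three values lie within the scatter of one another, so no order among them is claimed. Compound 1 and compound 2 differ in one place: chloro in place of bromo on an aromatic carbon. That change gave a 1.0-fold higher number from compound 1 to compound 2 (0.01 log units; within the scatter). Compound 3 carries a different core; how it differs from compound 1 is not broken down here. Compound 4, `CN(C)c1ccc(C2CC(c3ccccc3)=NN2C2=NC(=O)/C(=C3\C(=O)Nc4ccc(Cl)cc43)S2)cc1`, is not yet measured. It arises from compound 3 by the same change: chloro in place of bromo on an aromatic carbon. The step is expected to be a 1.0-fold higher number from compound 3 to compound 4 (0.01 log units; within the scatter), resting on a 1.0-fold higher number from compound 1 to compound 2 (0.01 log units; within the scatter) in the pair built on the core of compound 1, where bromo and chloro gave numbers within the scatter. Compound 4 is therefore estimated at 460 nM, expected between 230 nM and 920 nM in this assay.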

Compound 4, concentration for total growth inhibition: 430 nM
Estimate against measurement, compound 4: 1.1-fold (0.03 log units) above; the range from low to high includes it.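

On the core of compound 3, chloro in place of bromo on an aromatic carbon gives a 1.0-fold lower number from compound 3 to compound 4 (0.02 log units; within the scatter) in this assay. The change reads alike on both cores, with bromo and chloro not told apart on either: the same change on two cores in this assay, a 1.0-fold higher number (0.01 log units; within the scatter) from compound 1 to compound 2 and a 1.0-fold lower number (0.02 log units; within the scatter) from compound 3 to compound 4, 1.1-fold (0.03 log units) apart, within the scatter of two such steps. This supports treating the two groups as interchangeable on these two cores only; it does not show that the same holds on any further core, nor does it say anything about other groups on that carbon.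

The compounds shown leave open what happens with fluoro, a nitrile, an amine or a carboxylic acid on that aromatic carbon, or with hydrogen alone there. Also open, on these data alone, is whether the change behaves alike on a core whose aryl rings carry other groups, such as a longer alkoxy chain.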